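This account rests on a few compounds, and the source may have more. Where it says the series, first, only, none or still open, it means among the compounds named here.

Series notes, maximal response in the shared core with a cyclopropylmethyl-substituted triazole and a trifluoromethyl group.

Compound 1 `FC(F)(F)c1c(CN2CCCC(c3ccccc3)C2)ccn2c(CC3CC3)nnc12`: 240%
Compound 2 `CC1(c2ccccc2)CCCN(Cc2ccn3c(CC4CC4)nnc3c2C(F)(F)F)C1`: 278%
Compound 3 `Fc1ccccc1C1CCN(Cc2ccn3c(CC4CC4)nnc3c2C(F)(F)F)CC1`: 353%

All three were read in an assay on CHO cells for positive allosteric modulation of metabotropic glutamate receptor 2 (Homo sapiens), read by scintillation counting, with a stated time of 30 min; on this read-out higher numbers stand for larger maximal responses and lower numbers for smaller maximal responses. Compound 3 stands highest of the three numbers; compound 2 comes nearest and compound 1 lies furthest, both gaps beyond the scatter. Among the measured compounds shown here, the only single-change step within the measured set is a number 38 percentage points higher from compound 1 to compound 2 (beyond the scatter), which concerns a saturated ring carbon and carries no information on substitution of the phenyl ring.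

Compound 4 `Fc1cccc(F)c1C1CCN(Cc2ccn3c(CC4CC4)nnc3c2C(F)(F)F)CC1` differs from compound 3 by fluoro in place of hydrogen on an aromatic carbon; cut one bond further out, this reads 2-fluorophenyl to 2,6-difluorophenyl. For the measured compounds named here, no measured pair isolates a fluoro in place of hydrogen on the aromatic ring, so the size and direction of this step are unanchored. Without a comparable step, the expected change for compound 4 is small, a number 8 percentage points lower from compound 3 to compound 4 (within the scatter), not beyond the scatter. Compound 4 is therefore estimated at 345%, in the range 260% to 430%.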

Compound 4, largest response reached (Emax), in percent of the reference or control that the assay uses: 330%
The estimate for compound 4 lay 15 percentage points above the measured number; the measured number falls inside the stated range.
By their numbers in this assay, from the lowest: compound 1; then compound 2; then compound 4; then compound 3.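

In this assay, this pair gives the series its first reading for fluoro in place of hydrogen on an aromatic carbon, ortho to a large group and meta to a fluoro group: a number 23 percentage points lower from compound 3 to compound 4 (beyond the scatter). The change from 2-fluorophenyl to 2,6-difluorophenyl therefore lowers the maximal response modestly, and this single pair fixes the direction only for this one step. Nothing at hand explains the drop.

As far as these compounds go, whether the step belongs to fluoro itself remains open, and a chloro or methoxy group on the same aromatic carbon would test that. Among the compounds shown here, also open is what the single fluoro of compound 3 contributes, which a plain phenyl in its place would show.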